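Growing the Amide Acyl Group from Acetyl to Cyclopentylcarbonyl

The compounds below may be only part of what the source reports. "The series", "measured", "known", "first", "only" and "open" are said of these compounds alone.

Three compounds have so far been measured in an assay on HEK293 cells for negative allosteric modulation of metabotropic glutamate receptor 5 (Homo sapiens), read by FLIPR, with a stated time of 1 h; a higher number here means a weaker inhibitor, a lower number a stronger inhibitor:

Compound 1 `Fc1cccc(C#Cc2nc3c(s2)CN(C2CCOC2)CC3)c1` gives 400 nM.
Compound 2 `CC(=O)N1CCc2nc(C#Cc3ccccc3)sc2C1` gives 90 nM.
Compound 3 `O=C(C1CC(F)(F)C1)N1CCc2nc(C#Cc3cccc(F)c3)sc2C1` gives only a limit, > 10000 nM.

Of the two proper numbers, compound 2 has the lower one, and compound 1 sits clearly higher, beyond the usual scatter. The value for compound 3 is not a number but a limit of the assay (the limit of > 10000 nM in this assay, at which 1 of the 3 values shown sits).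

Compound 4 `O=C(C1CCCC1)N1CCc2nc(C#Cc3ccccc3)sc2C1` has not yet been measured. It differs from compound 2 in one place: cyclopentyl in place of methyl on a carbonyl carbon. Within the data shown here, the only measured step that changes the group on the ring amine nitrogen is an at least 25-fold higher number from compound 1 to compound 3 (1.39 log units; beyond the scatter); there (3,3-difluorocyclobutyl)carbonyl replaced oxolan-3-yl, not a smaller acyl group, so it bears on the present step only indirectly. Compound 2 and compound 3 differ in more than one place, so their values can only be set side by side: the small acetyl goes with the lowest number, the larger ring-carrying acyl group with a limit. A larger acyl group is therefore expected to weaken inhibition, though perhaps less sharply. Compound 4 is estimated at 800 nM, between 200 nM and 5000 nM, an expected step of an 8.9-fold higher number from compound 2 to compound 4 (0.95 log units; beyond the scatter) toward weaker inhibition.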

Compound 4, half-maximal inhibitory concentration: > 10000 nM
Compound 4: a limit, no number; the forecaster's own chance of this, stated with the estimate: 20%; middle value at least 12-fold (1.09 log units) away from the limit.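

In this assay, among these compounds, the only earlier step on this ring nitrogen replaced oxolan-3-yl with an acyl group, which changed the kind of group attached, whereas here the amide stays in place and only the group on the carbonyl carbon changes, giving an at least 110-fold higher number from compound 2 to compound 4 (2.04 log units; beyond the scatter). This shows that the acetyl of compound 2 cannot be enlarged freely: going from methyl to cyclopentyl on the carbonyl carbon is enough on its own to lose nearly all measurable inhibition. Compound 4 gives > 10000 nM, which is a limit and not a number, and this outcome is no longer a single case: the limit of > 10000 nM in this assay, at which 2 of the 4 values shown sit.

The compounds shown leave open how large the group on the carbonyl carbon can become before the number starts to rise, for instance whether ethyl, isopropyl or cyclopropyl stays close to methyl or already behaves like cyclopentyl. They also leave open whether a ring of similar size that carries an oxygen or a nitrogen, such as a tetrahydropyranyl or a piperidinyl group, would fare any better on that same carbonyl carbon.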